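Chain-terminal ammonium replacement in the oxime series

The compounds below may be only part of what the source reports. "The series", "measured", "known", "first", "only" and "open" are said of these compounds alone.

Measured so far:
compound 1, `C[n+]1ccn(COC2CCCC[C@H]2S(C)(=O)=O)c1/C=N/O`: -2.59
compound 2, `CN(C)CCCn1cc[n+](C)c1/C=N/O`: < -3
compound 3, `CCN(CC)CCCn1cc[n+](C)c1/C=N/O`: -2.78

In a physicochemical assay for lipophilicity (on this read-out lower numbers stand for lower lipophilicity and higher numbers for higher lipophilicity), compound 2 returns only a limit, < -3, which is the assay floor noted as the limit of < -3 in this assay, at which 1 of the 3 values shown sits. Compound 2 therefore stands at or under the bottom of the measured range, with compound 3 and compound 1 both giving numbers above that floor.

Compound 4, `C[n+]1ccn(CC[N+](C)(C)C)c1/C=N/O`, differs from compound 2 by a group of 4 heavy atoms (3 carbon, 1 nitrogen; no ring) in place of a group of 4 heavy atoms (3 carbon, 1 nitrogen; no ring), on a saturated chain carbon, two bonds along the chain from an aromatic nitrogen; the leaving group carries no net charge and one hydrogen-bond acceptor, the entering group carries a net charge of +1 and no acceptor.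

Within the data shown here, the only measured step on this chain end is a number at least 0.22 log units higher from compound 2 to compound 3 (that floor lies within the scatter), a change of alkyl size at a different place and without a charge change, so it bears on compound 4 only loosely. Among the measured compounds shown here, no measured step introduces a charged group. Given that compound 2 already sits at the limit, compound 4 is expected to sit at or past that limit, with the step that the limit leaves unreadable from compound 2 to compound 4 estimated as downward. Compound 4 is estimated at -3.4 in this assay, within -4 to -2.9, most likely reported again only as a limit.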

Compound 4, distribution coefficient: -2.61
Beside the measured number, compound 4's estimate is 0.79 log units below it; the measured number lies above the stated range.
By their numbers in this assay, from the lowest: compounds 3, 4 and 1 (each within the scatter of the next). At a limit, below all of these: compound 2.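

In this assay, placing the group with a net charge of +1 on a saturated chain carbon, two bonds along the chain from an aromatic nitrogen, gives a number at least 0.39 log units higher from compound 2 to compound 4 (beyond the scatter) and shows that this change does not lower the read-out. The floor of this step lies beyond the scatter, which the floor of the earlier diethylamino step (a number at least 0.22 log units higher from compound 2 to compound 3 (that floor lies within the scatter)) does not. Compound 2 stands at a limit, so only a floor can be read for either step: the limit of < -3 in this assay, at which 1 of the 4 values shown sits.

As far as these compounds go, how far compound 2 lies under its limit remains open, and with it the full size of both steps. Also open, from the compounds shown here alone, is how the read-out at this chain end responds to a longer chain, a pyrrolidine or a carboxylic acid in place of the charged group.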